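Ring size at the ether of compound 1

The compounds below may be only part of what the source reports. "The series", "measured", "known", "first", "only" and "open" are said of these compounds alone.

Compound 1 `NC(=O)c1ccc(-c2cccnc2)cc1OC1CCNCC1` gives 1100 nM in an assay on cells for inhibition of MAP kinase-interacting serine/threonine-protein kinase 1 (Homo sapiens), read by mobility shift assay, with stated times of 10 min and 60 min, in the presence of a further agent that is not named here; on this read-out higher numbers stand for weaker inhibition and lower numbers for stronger inhibition.
Compound 2 `Cc1[nH]ncc1-c1cncc(-c2ccc(C(N)=O)c(OC(C)C)c2)c1` gives 54 nM in this assay.
Compound 3 `CC(C)Oc1cc(-c2cncc(-c3cnn(C(C)C)c3)c2)ccc1C(N)=O` gives 85 nM in this assay.

Of the three numbers, compound 1 has the highest in this assay; compound 3 stands nearest with a number that is lower beyond the scatter, and compound 2 stands furthest with a number that is lower beyond the scatter as well. The only measured step among these compounds, a 1.6-fold higher number from compound 2 to compound 3 (0.20 log units; within the scatter), concerns a change of the pyrazole group on the aromatic carbon and lies within the scatter; it does not touch the ether side chain.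

Compound 4 `NC(=O)c1ccc(-c2cccnc2)cc1OC1CCNC1` is compound 1 with one change: pyrrolidin-3-yl in place of piperidin-4-yl on an oxygen on an aromatic ring. Among the compounds with values here, no measured step in this set bears on such a change at the oxygen on the aromatic ring, so the expectation rests on compound 1 alone, whose value in this assay is 1100 nM. With nothing to suggest a move in either direction, the step of no change at the digits printed from compound 1 to compound 4 (within the scatter) is expected to stay within the scatter. Compound 4 is therefore estimated at 1100 nM in this assay, with a range from 450 nM to 2700 nM.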

Compound 4, half-maximal inhibitory concentration: 1900 nM
The estimate for compound 4 lay 1.7-fold (0.24 log units) below the measured number; the measured number falls inside the stated range.
By their numbers in this assay, from the lowest: compounds 2 and 3 (each within the scatter of the next); then compounds 1 and 4 (each within the scatter of the next).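

In this assay, within the data shown here, the change at the oxygen on the aromatic ring gives a 1.7-fold higher number from compound 1 to compound 4 (0.24 log units; within the scatter), the first step in this set that touches the ether side chain rather than the pyrazole group. On this single pair, the six-membered non-aromatic ring of piperidin-4-yl and the five-membered non-aromatic ring of pyrrolidin-3-yl cannot be told apart, so this change of ring size at the oxygen does not shift the number beyond the scatter. Nothing available here bears on this result or offers an account of it.

Compound 2 and compound 3 differ from compound 1 and compound 4 in more than one place, so these figures do not show whether the two rings would also be indistinguishable on a core carrying a pyrazole group, or how much of the gap to those compounds belongs to the ether side chain. Also open, going by these compounds, is whether the number would hold with a smaller ring such as azetidin-3-yl, or an open chain such as 2-aminoethyl, on the same oxygen.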